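Cytotoxicity notes: the step from compound 3 to compound 4

A few compounds are considered here, and "the series" means these few. Any claim that something is new, unique, unknown or untested is made for them only; others in the source may bear on it.

Compound 3 `N#Cc1ccc(Cn2ccc3nc(-c4ccccc4)nc-3c2)cc1` has been run in an ADME assay on MDBK cells (Bos taurus) for cytotoxicity; on this read-out lower numbers stand for higher toxicity in this test and higher numbers for lower toxicity in this test. There compound 3 returns only a limit, > 100000 nM. Its two analogues sit at the same ceiling. Compound 1 `Fc1ccc(Cn2ccc3nc(-c4ccccc4)nc-3c2)cc1` also returns a limit in this assay, > 100000 nM. Compound 2 `N#Cc1cccc(Cn2ccc3nc(-c4ccccc4)nc-3c2)c1` likewise returns a limit in this assay, > 100000 nM. Because all three values sit at the limit of > 100000 nM in this assay, at which 3 of the 3 values shown sit, none of the steps among them can be sized: a step that the two limits leave unreadable from compound 1 to compound 3, a step that the two limits leave unreadable from compound 2 to compound 3 and a step that the two limits leave unreadable from compound 1 to compound 2. Compound 3 thus stands at the ceiling with both neighbours, with no order among the three.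

Compound 4 `Clc1ccc(Cn2ccc3nc(-c4ccccc4)nc-3c2)s1` differs from compound 3 by 5-chlorothiophen-2-yl in place of 4-cyanophenyl on a saturated chain carbon bound to an aromatic nitrogen. The measured steps bear on this change only in that earlier exchanges of the group on the same saturated chain carbon, cyano for fluoro and 4-cyanophenyl for 3-cyanophenyl, never moved any compound off the limit. No readable step is at hand, so no movement beyond the scatter is expected in this assay, in either direction. Compound 4 is expected to stay at the ceiling too, estimated at 100000 nM with a range of 40000 nM to 300000 nM. The expected step is then a number no higher from compound 3 to compound 4 (the limit leaves the size open).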

Compound 4, half-maximal cytotoxic concentration: > 100000 nM
Compound 4: no number, only a limit (the forecaster's own chance of this, stated with the estimate: 80%); the middle value sits exactly at the limit.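

Compound 4 returns only a limit in this assay, like compound 1, compound 2 and compound 3, so none of its steps from these three can be read: the limit of > 100000 nM in this assay, at which 4 of the 4 values shown sit.

The compounds shown leave open how far each true value lies past the limit, and whether any group on the saturated chain carbon bound to an aromatic nitrogen changes cytotoxicity.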